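Swapping the Aryl Ether Cap on a Spiro Diaminotriazine

The source may hold more compounds than are shown below. What is called first, only, known or untested is meant among the compounds shown, and "the series" means these compounds.

Compound 1 `COc1ccc(OCCCON2C(N)=NC(N)=NC23CCOCC3)cc1` carries a 4-methoxyphenyl on an oxygen on a saturated carbon whose other neighbour is a saturated chain carbon. In an assay on isolated protein for inhibition of Dihydrofolate reductase (Homo sapiens), read by spectrophotometry, using NADPH, with stated times of 5 s and 6 min, tested at 50 uM (on this read-out higher numbers stand for a stronger effect at the one concentration tested and lower numbers for a weaker effect), compound 1 gives "not determined" (no result reported), so it has no number of its own to stand on. Within the data shown here, the only measured member of the series is compound 2 `NC1=NC2(CCSCC2)N(OCCCOc2cc(Cl)c(Cl)cc2Cl)C(N)=N1`, which differs from compound 1 in both its core and its aryl group; in this assay compound 2 gives 94.4%. Compound 3 `NC1=NC2(CCOCC2)N(OCCCOc2cccc(Br)c2)C(N)=N1` is the next step from compound 1: 3-bromophenyl in place of 4-methoxyphenyl on an oxygen on a saturated carbon. Among the measured compounds shown here, with no measured pair sharing a single change, the size of this step in this assay cannot be read from the data; what can be said is that compound 2, with a halogenated aryl group, reaches a high value there. On that basis compound 3 is expected to give about 85%, with a plausible range from 55% to 98%.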

Compound 3, a percentage reported as inhibition, at one concentration (the size of the read-out at that concentration, not a potency): 85.8%
The estimate for compound 3 lay 0.8 percentage points below the measured number; the measured number falls inside the stated range.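

No step can be read from compound 1 to compound 3 in this assay, where compound 1 gives "not determined" (no result reported) and compound 3 gives 85.8%. Nothing shown here explains the value of compound 3. The compounds shown leave open what replacing 4-methoxyphenyl with 3-bromophenyl does on its own.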